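A Benzylamide Substituent Swap Before Measurement

A few compounds are considered here, and "the series" means these few. Any claim that something is new, unique, unknown or untested is made for them only; others in the source may bear on it.

Measured so far in a functional assay on SJ-G2 cells (Homo sapiens) for inhibition, read by MTT assay, with a stated time of 72 h; a lower number here means a stronger inhibitor of growth, a higher number a weaker inhibitor of growth:
compound 1 `N#C/C(=C\c1c(F)c(F)c(F)c(F)c1F)C(=O)c1c[nH]c2ccccc12` — 14000 nM
compound 2 `COc1ccc(CNC(=O)/C(C#N)=C/c2ccoc2)cc1` — 8000 nM
compound 3 `COc1ccc(CNC(=O)/C(C#N)=C/c2cccc3ccccc23)cc1` — 15000 nM

Compound 3 carries the highest of the three numbers in this assay, but its gaps to compound 1 and to compound 2 both lie within the scatter, so no order among the three is claimed. Compound 4 `N#C/C(=C\c1cccc2ccccc12)C(=O)NCc1ccc(Cl)c(Cl)c1` differs from compound 3 in one place: 3,4-dichlorophenyl in place of 4-methoxyphenyl on a saturated chain carbon bound to an amide-type nitrogen. For the measured compounds named here, no measured pair shows a change of this kind, so its size is unknown. All three measured values of this assay sit close together. No step beyond the scatter is expected in either direction. Compound 4 is therefore expected to give about 10000 nM, within 4000 nM to 30000 nM. The estimated step from compound 3 to compound 4 is a 1.5-fold lower number from compound 3 to compound 4 (0.18 log units; within the scatter).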

Compound 4, concentration for 50% growth inhibition: 13000 nM
Compound 4: the middle estimate sits 1.3-fold (0.11 log units) below what was measured; the range from low to high includes it.
By their numbers in this assay, from the lowest: compounds 2, 4, 1 and 3 (each within the scatter of the next).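

In this assay, placing 3,4-dichlorophenyl where 4-methoxyphenyl stood, on a saturated chain carbon bound to an amide-type nitrogen, gives a 1.2-fold lower number from compound 3 to compound 4 (0.06 log units; within the scatter). For the compounds shown here, this is the first measured pair at this position, and it shows that exchanging this methoxy-bearing ring for a dichloro-bearing one leaves the number within the scatter. No measurement available here bears on why. From the compounds shown here alone, whether an aminophenyl or carboxyphenyl group at this place, or a longer chain, would move the number stays open. So does whether this swap would behave alike on the core of compound 2.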